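Pyrimidopyridinone sulfones: ring-nitrogen substitution and K562 inhibition

The compounds below may be only part of what the source reports. "The series", "measured", "known", "first", "only" and "open" are said of these compounds alone.

Measured so far:
compound 1, `Cn1c(=O)c(S(=O)(=O)c2ccc(F)cc2F)cc2cnc(Nc3ccc4[nH]c(C(=O)O)cc4c3)nc21`: 10000 nM
compound 2, `O=c1[nH]c2nc(Nc3ccc4[nH]ccc4c3)ncc2cc1S(=O)(=O)c1ccc(F)cc1F`: 15000 nM
compound 3, `Cn1c(=O)c(S(=O)(=O)c2ccc(Cl)cc2)cc2cnc(Nc3cccc4[nH]ccc34)nc21`: 5000 nM

In a functional assay on K562 cells (Homo sapiens) for inhibition, read by trypan blue exclusion, with a stated time of 72 h (a higher number here means a weaker inhibitor, a lower number a stronger inhibitor), compound 2 gives 15000 nM, the highest of the three numbers. Compound 1 gives 10000 nM, which lies within the scatter of compound 2; compound 3 gives 5000 nM, which stands beyond the scatter below compound 2. Within the data shown here, compounds 1 and 3 each differ from compound 2 in more than one place, so no single step between measured compounds is available.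

Compound 4, `COC(=O)Cn1c(=O)c(S(=O)(=O)c2ccc(F)cc2F)cc2cnc(Nc3ccc4[nH]ccc4c3)nc21`, is not yet measured. It differs from compound 2 at one place: (methoxycarbonyl)methyl in place of hydrogen on an aromatic nitrogen. The change is a substitution on an aromatic nitrogen of a six-membered aromatic ring with one nitrogen, ortho to a fused ring and meta to a (2,4-difluorophenyl)sulfonyl group, the rest of the shared core being unchanged.

Among the measured compounds shown here, with no measured step across this position, the step from compound 2 to compound 4 in this assay is expected to be small, at most a modest move toward a lower number and possibly none beyond the scatter: a 1.7-fold lower number from compound 2 to compound 4 (0.22 log units; within the scatter). Compound 4 is therefore estimated at 9000 nM, with a range from 3000 nM to 27000 nM.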

Compound 4, half-maximal inhibitory concentration: 5000 nM
Compound 4: the middle estimate sits 1.8-fold (0.26 log units) above what was measured; the range from low to high includes it.
By their numbers in this assay, from the lowest: compounds 3, 4, 1 and 2 (each within the scatter of the next, the first and the last beyond it).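

In this assay, among these compounds, (methoxycarbonyl)methyl in place of hydrogen on the aromatic nitrogen gives a 3.0-fold lower number from compound 2 to compound 4 (0.48 log units; beyond the scatter) and provides the first single-place step at this position. The step lies beyond the scatter, so this nitrogen need not carry hydrogen and can bear this chain with no loss in this read-out. Nothing available accounts for the change in number.

Compounds 1 and 3 carry a methyl group on this nitrogen but differ from compound 2 in more than one place, so they do not show whether the step needs the ester or follows from any substituent there. On these data alone, that stays open until a plain methyl group, a carboxylic acid in place of the methyl ester, or a longer chain ending in an amine is compared on the otherwise unchanged structure of compound 2.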